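Swapping the aryl group on the exocyclic double bond

The source may report more compounds than this note shows. Statements on the series, on what has been measured and on what is new or still open speak of the compounds shown alone.

Compound 3 `CN(C)c1ccc(/C=C2\C(=O)N(c3c(Cl)cccc3Cl)c3ccccc32)cc1` reaches only a limit in a functional assay on HuTu80 cells (Homo sapiens) for cytotoxicity, read by MTT assay, with a stated time of 72 h (on this read-out lower numbers stand for an effect already at smaller amounts and higher numbers for an effect only at larger amounts of compound), giving < 1 ug/mL, which is the lower limit of the assay. The same limit holds for compound 2 `Cc1ccc2nc(Cl)c(/C=C3\C(=O)N(c4c(Cl)cccc4Cl)c4ccccc43)cc2c1C`, which gives < 1 ug/mL, so the limit of < 1 ug/mL in this assay, at which 2 of the 3 values shown sit, marks where both stand. Compound 1 `O=C1/C(=C\c2c(Cl)cccc2Cl)c2ccccc2N1c1c(Cl)cccc1Cl` gives 100 ug/mL in this assay. The unmeasured compound 4 `O=C1/C(=C\c2cccc(Cl)c2)c2ccccc2N1c1c(Cl)cccc1Cl` differs from compound 3 only by 3-chlorophenyl in place of 4-(dimethylamino)phenyl on a double-bonded chain carbon bound to a double-bonded ring carbon. Within the data shown here, the one measured step at this place, an at least 100-fold lower number from compound 1 to compound 3 (2.00 log units; beyond the scatter), shows that exchanging 2,6-dichlorophenyl for 4-(dimethylamino)phenyl here moved the number far. Reversing toward a chlorine-bearing phenyl, compound 4 is therefore expected to show a rise, estimated as an at least 30-fold higher number from compound 3 to compound 4 (1.47 log units; beyond the scatter). The estimate for compound 4 is 30 ug/mL, with a range from 5 ug/mL to 100 ug/mL.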

Compound 4, concentration for half-maximal effect: 7 ug/mL
The estimate for compound 4 lay 4.3-fold (0.63 log units) above the measured number, and the stated range covers the measured number.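

With 3-chlorophenyl on the double-bonded chain carbon, the number falls between those of the two earlier groups: the exchange for 4-(dimethylamino)phenyl gives an at least 7.0-fold higher number from compound 3 to compound 4 (0.84 log units; beyond the scatter), and the exchange for 2,6-dichlorophenyl gives a 14-fold lower number from compound 1 to compound 4 (1.15 log units; beyond the scatter). A chlorine-bearing phenyl here therefore need not give a number as high as that of compound 1. The true size of the first step stays unknown, as compound 3 sits at a limit of the assay: the limit of < 1 ug/mL in this assay, at which 2 of the 4 values shown sit.

From the compounds shown here alone, how an unsubstituted phenyl or a 4-methoxyphenyl would read at this place remains open. So does the effect of a carboxylic acid on this phenyl.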